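The source may hold more compounds than are shown below. What is called first, only, known or untested is meant among the compounds shown, and "the series" means these compounds.

In a functional assay on B16 cells (Mus musculus) for cytotoxicity, read by MTT assay, with a stated time of 48 h (a higher number here means a weaker inhibitor, a lower number a stronger inhibitor), compound 1 `C#CC(=O)Nc1cccc(C#C)c1` gives 300 nM, and compound 2 `C#Cc1cccc(NC(=O)c2cn(CCOC(C)=O)nn2)c1` gives 25100 nM. Compound 3 `C#Cc1ccc(NC(=O)c2cn(Cc3ccccc3)nn2)cc1` yields no number, only a limit of the assay, > 100000 nM. This makes it a difficult starting point, since the comparison begins from a bound and not from a measured value.

Compound 4 `C#Cc1ccc(NC(=O)c2cn(CCOC(C)=O)nn2)cc1` differs from compound 3 in one place, on a saturated chain carbon bound to an aromatic nitrogen. There, acetoxymethyl stands in place of phenyl, which can also be read as benzyl changing to 2-acetoxyethyl (acetoxymethyl in place of phenyl on a saturated chain carbon bound to an aromatic nitrogen).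

Among the measured compounds shown here, no pair of measured compounds shows this change directly, so the best guide is a less direct one. Compound 2 carries the same 2-acetoxyethyl group and reads 25100 nM in this assay, although it is not otherwise identical to compound 4. On that basis, a moderate step towards a lower number, and so towards a stronger inhibitor, is expected, though the result could still come back as a limit. The estimated change runs an at least 2.5-fold lower number from compound 3 to compound 4 (0.39 log units; beyond the scatter). For compound 4 the expected value is 40000 nM, with an estimated range of 12000 nM to 100000 nM.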

Compound 4, half-maximal inhibitory concentration: 79000 nM
Compound 4: middle estimate off by 2.0-fold (0.30 log units), on the low side, and the stated range covers the measured number.
By their numbers in this assay, from the lowest: compound 1; then compound 2; then compound 4. At a limit, above all of these: compound 3.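

Among the compounds shown here, the change of phenyl to acetoxymethyl on a saturated chain carbon bound to an aromatic nitrogen, which turns benzyl into 2-acetoxyethyl, is the first change at this position that can be followed in this assay, and it gives an at least 1.2-fold lower number from compound 3 to compound 4 (0.10 log units; that floor lies within the scatter). Compound 3 sits at a limit of the assay, so the step is known only as a floor, and that floor alone does not clear the usual scatter: the limit of > 100000 nM in this assay, at which 1 of the 4 values shown sits.

For the compounds shown here, compound 4, at 79000 nM, gives this position a measured number on this core for the first time, and later changes at the same place can be compared against it as a real value and not a bound.

The compounds shown leave open whether the loss of the aromatic ring or the arrival of the acetoxymethyl oxygens accounts for the step, since both happen in the one change. They also leave open how this assay would read with 2-hydroxyethyl, 2-aminoethyl or a longer chain carrying a carboxylic acid in place of 2-acetoxyethyl.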